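Three limits and one open fluorine swap

The source may hold more compounds than are shown below. What is called first, only, known or untested is meant among the compounds shown, and "the series" means these compounds.

- compound 1 `Cc1ccccc1NNC(=O)c1ccc(NS(=O)(=O)c2cnc(O)nc2O)cc1`: > 20000 nM
- compound 2 `Cc1cccc(NNC(=O)c2ccc(NS(=O)(=O)c3cnc(O)nc3O)cc2)c1`: > 20000 nM
- compound 3 `Cc1cccc(NNC(=O)c2ccccc2NS(=O)(=O)c2cnc(O)nc2O)c1`: > 20000 nM

These three entries come from a functional assay on MDA-MB-231 cells (Homo sapiens) for antiproliferative activity, read by MTT assay, with a stated time of 24 h (a lower number here means a stronger inhibitor, a higher number a weaker inhibitor), and each one is a limit of the assay, not a measured number. Within the data shown here, compound 3 therefore has no exact position, and the limit of > 20000 nM in this assay, at which 3 of the 3 values shown sit, shows that all the compounds measured so far share this limit.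

Compound 4 `O=C(NNc1ccccc1F)c1ccccc1NS(=O)(=O)c1cnc(O)nc1O` has 2-fluorophenyl in place of 3-methylphenyl on an amine nitrogen, a change counted as 2-fluorophenyl in place of 3-methylphenyl on an amine nitrogen.

Among the measured compounds shown here, the only measured step is a step that the two limits leave unreadable from compound 1 to compound 2, a move of the methyl group's phenyl from 2-methylphenyl to 3-methylphenyl. It offers no size to carry over, so it cannot predict a gain or a loss here. The expectation therefore rests on compound 3 at its limit of > 20000 nM, and no clear step in either direction is expected in this assay.

For compound 4 the estimated value is 25000 nM, with an expected range from 8000 nM to 60000 nM.

The expected change is a step that the limit leaves unreadable from compound 3 to compound 4.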

Compound 4, half-maximal inhibitory concentration: > 20000 nM
Compound 4: a limit, no number (the forecaster's own chance of this, stated with the estimate: 70%); the middle value lies beyond the limit too.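

Compound 3 and compound 4 both give only a limit of the assay, not a number, so no step can be read between them: the limit of > 20000 nM in this assay, at which 4 of the 4 values shown sit.

The compounds shown leave open how strongly any of them acts in this assay, and whether 2-fluorophenyl in place of 3-methylphenyl changes that at all.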